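The compounds below may be only part of what the source reports. "The series", "measured", "known", "first", "only" and "open" are said of these compounds alone.

Compound 2 `CN1CCN(c2nc3ccccc3n2-c2ccccc2)CC1` carries the highest number of the two compounds measured in a functional assay on ileum for inhibition of histamine H1 receptor (Cavia porcellus) (on this read-out lower numbers stand for stronger inhibition and higher numbers for weaker inhibition), giving 760 nM. Within the data shown here, the only other measured compound, compound 1 `CCCCOCCn1c(N2CCCN(C)CC2)nc2ccccc21`, gives 10 nM in this assay, and the gap between the two lies well beyond the usual scatter. The next compound, compound 3 `CCCCOCCn1c(N2CCN(C)CC2)nc2ccccc21`, has not yet been measured. It differs from compound 2 in one place: 2-butoxyethyl in place of phenyl on an aromatic nitrogen. Among the measured compounds shown here, no pair of measured compounds differs in exactly this way, so the size of the step cannot be read from a comparable change. For the measured compounds named here, still, the entering group is the one that compound 1 carries on its own aromatic nitrogen, and compound 1 gives 10 nM, so a large move toward lower numbers is expected; the step from compound 2 to compound 3 is estimated as a 38-fold lower number from compound 2 to compound 3 (1.58 log units; beyond the scatter). Compound 3 is therefore expected to give about 20 nM, within a range from 5 nM to 120 nM.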

Compound 3, half-maximal inhibitory concentration: 38 nM
For compound 3 the middle estimate is 1.9-fold (0.28 log units) below the measured one, and the stated range covers the measured number.
By their numbers in this assay, from the lowest: compound 1; then compound 3; then compound 2.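

Among these compounds, with the 4-methylpiperazin-1-yl group held fixed, 2-butoxyethyl in place of phenyl on the aromatic nitrogen gives a 20-fold lower number from compound 2 to compound 3 (1.30 log units; beyond the scatter) in this assay and so puts a first size on a change at this position, a large one. With 2-butoxyethyl held fixed, 4-methylpiperazin-1-yl in place of 4-methyl-1,4-diazepan-1-yl on the aromatic carbon gives a 3.8-fold higher number from compound 1 to compound 3 (0.58 log units; beyond the scatter) and shows that the amine ring also counts, with a modest step beyond the scatter. Both places thus affect the read-out, each seen through a single pair.

The compounds shown leave open whether the ether oxygen of 2-butoxyethyl matters, which a plain alkyl chain or a benzyl group on this nitrogen would test, and whether the step between the amine rings holds with phenyl on the nitrogen. Nothing given here accounts for either step.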